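Adding a Second Methoxy to a Cytotoxic Benzophenone Amide

The source may hold more compounds than are shown below. What is called first, only, known or untested is meant among the compounds shown, and "the series" means these compounds.

Compound 1 `COc1ccc(C(=O)c2cc(OC)c(OC)c(OC)c2)cc1NC(=O)/C=C/c1cc(OC)c(OC)c(OC)c1` was tested in a functional assay on DU-145 cells (Homo sapiens) for cytotoxicity, read by MTT assay, with a stated time of 72 h (on this read-out lower numbers stand for stronger inhibition and higher numbers for weaker inhibition), and compound 1 gives 6300 nM there. Within the data shown here, only one other measured compound stands beside it: compound 2 `COc1cccc(/C=C/C(=O)Nc2cc(C(=O)c3cc(OC)c(OC)c(OC)c3)ccc2OC)c1` gives 6200 nM in this assay, and the change a 1.0-fold lower number from compound 1 to compound 2 (0.01 log units; within the scatter) lies within the scatter, so compound 1 stands at the top of these two numbers only in the narrowest sense, with nothing separating it from compound 2.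

Compound 3 `COc1cc(C(=O)c2cc(OC)c(OC)c(OC)c2)cc(NC(=O)/C=C/c2cc(OC)c(OC)c(OC)c2)c1OC` is reached from compound 1 by a change in a different part of the molecule: methoxy in place of hydrogen on an aromatic carbon, on an aromatic carbon ortho to a methoxy group and meta to two large groups. Among the measured compounds shown here, no measured step touches this ring position. For the measured compounds named here, the single step known, from compound 1 to compound 2, altered a distant ring and did not move the number, so a step of a 1.1-fold lower number from compound 1 to compound 3 (0.02 log units; within the scatter) in this assay is expected for compound 3, with no direction beyond the scatter. Compound 3 is estimated at 6000 nM in this assay, within 2500 nM to 15000 nM.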

Compound 3, half-maximal inhibitory concentration: 6600 nM
Beside the measured number, compound 3's estimate is 1.1-fold (0.04 log units) below it; measured number inside the range.
By their numbers in this assay, from the lowest: compounds 2, 1 and 3 (each within the scatter of the next).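

In this assay, placing a methoxy on this aromatic carbon, ortho to a methoxy group and meta to two large groups, gives a 1.0-fold higher number from compound 1 to compound 3 (0.02 log units; within the scatter), so the extra group leaves compound 3 indistinguishable from compound 1. This is the first measured change on this ring, and together with a 1.0-fold lower number from compound 1 to compound 2 (0.01 log units; within the scatter), it means that both single changes shown, made in different parts of the molecule, stay within the usual scatter of the assay. No supporting measurement is available to explain this result.

Going by these compounds, it remains open whether a different group on this carbon, such as an amine, a carboxylic acid or a longer chain like ethoxy, would separate itself from hydrogen in this assay. Also open, on these data alone, is how this added methoxy would read alongside the 3-methoxyphenyl group of compound 2.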